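The source may report more compounds than this note shows. Statements on the series, on what has been measured and on what is new or still open speak of the compounds shown alone.

Series so far:
- compound 1 `COc1cc2ncnc(Nc3cc(-c4ccc(F)cc4)[nH]n3)c2cc1OC`: < 100000 nM
- compound 2 `COc1cc2ncnc(Nc3cc(-c4ccc(Cl)cc4)[nH]n3)c2cc1OC`: 79500 nM

Going by the values given here, in a functional assay on MDA-MB-468 cells (Homo sapiens) for cytotoxicity, read by MTT assay (a higher number here means a weaker inhibitor, a lower number a stronger inhibitor), compound 2 gives 79500 nM, the only actual number so far. Compound 1 is reported as < 100000 nM, which is a limit.

Compound 3 `COc1ccc(-c2cc(Nc3ncnc4cc(OC)c(OC)cc34)n[nH]2)cc1` keeps the shared core and changes 4-chlorophenyl to 4-methoxyphenyl, with methoxy in place of chloro on an aromatic carbon, para to a large group: methoxy in place of chloro on an aromatic carbon.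

Among the compounds with values here, the only measured step bearing on this is a step that the limit leaves unreadable from compound 1 to compound 2, and it concerns the same place on the ring. Within the data shown here, its size cannot be read, and the sole evidence on it is the limit of < 100000 nM in this assay, at which 1 of the 2 values shown sits. Among the measured compounds shown here, with no measured step to scale from, no shift in either direction can be argued in this assay. The expected result is a 1.1-fold lower number from compound 2 to compound 3 (0.06 log units; within the scatter), which means no step beyond the scatter. For compound 3 the estimate is 70000 nM, with an expected range of 25000 nM to 130000 nM.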

Compound 3, half-maximal inhibitory concentration: 45300 nM
For compound 3 the middle estimate is 1.5-fold (0.19 log units) above the measured one, within the range that was stated.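

In this assay, going by these compounds alone, 4-methoxyphenyl in place of 4-chlorophenyl gives the first readable step at this position, a 1.8-fold lower number from compound 2 to compound 3 (0.24 log units; within the scatter), so this swap on an aromatic carbon, para to a large group, stays inside the usual scatter. The entering methoxy adds a hydrogen-bond acceptor that chloro lacks, and between these two compounds no shift beyond the scatter accompanies that difference. Compound 1 carries a limit, so the steps from it cannot be read: the limit of < 100000 nM in this assay, at which 1 of the 3 values shown sits.

Whether any group at this position can move the number beyond the scatter remains open, since the compounds shown carry only fluoro, chloro or methoxy there. An amine, a carboxylic acid or a longer chain such as butoxy on the same aromatic carbon would bear on that question.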